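The source may hold more compounds than are shown below. What is called first, only, known or untested is meant among the compounds shown, and "the series" means these compounds.

For the measured compounds named here, in a functional assay on MCF7 cells (Homo sapiens) for inhibition, read by MTT assay, with a stated time of 3 days (a higher number here means a weaker inhibitor, a lower number a stronger inhibitor), compound 2 `COCOc1ccccc1/C=C/CCCOc1cc(/C=C\c2cc(OC)c(OC)c(OC)c2)ccc1OC` gives 4400 nM, the lower of the two numbers so far, and compound 1 `COc1cccc(/C=C/CCCOc2cc(/C=C\c3cc(OC)c(OC)c(OC)c3)ccc2OC)c1` gives 41000 nM. Compound 3 `COCOc1cccc(/C=C/CCCOc2cc(/C=C\c3cc(OC)c(OC)c(OC)c3)ccc2OC)c1` is the next case, with 3-(methoxymethoxy)phenyl in place of 2-(methoxymethoxy)phenyl on a double-bonded chain carbon bound to a double-bonded chain carbon. Going by the values given here, only one measured step bears on this, a 9.3-fold lower number from compound 1 to compound 2 (0.97 log units; beyond the scatter), which brought in 2-(methoxymethoxy)phenyl in place of 3-methoxyphenyl. That step changes the group and its printed number together, so the data do not separate the two. Compound 3 keeps the methoxymethoxy group of compound 2 but has the 3-substituted name, as compound 1 does, so part of that step is expected to be lost. The expected change is a 2.7-fold higher number from compound 2 to compound 3 (0.44 log units; beyond the scatter), toward a higher number. For compound 3 the estimate is 12000 nM, with an expected range of 3500 nM to 40000 nM.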

Compound 3, half-maximal inhibitory concentration: 8000 nM
Compound 3: the middle estimate sits 1.5-fold (0.18 log units) above what was measured; the range from low to high includes it.
By their numbers in this assay, from the lowest: compounds 2 and 3 (each within the scatter of the next); then compound 1.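

In this assay, 3-(methoxymethoxy)phenyl in place of 2-(methoxymethoxy)phenyl gives a 1.8-fold higher number from compound 2 to compound 3 (0.26 log units; within the scatter), so the two placements of the methoxymethoxy group cannot be told apart in this assay. With the 3-substituted name held constant, extending methoxy to methoxymethoxy gives a 5.1-fold lower number from compound 1 to compound 3 (0.71 log units; beyond the scatter), which isolates a change in the group itself and shows that the earlier gain does not depend on the move to the 2-substituted phenyl. No separate measurement bears on the origin of either step.

Still open, as far as these compounds go, is whether the methoxymethoxy group can be replaced by a hydroxy group, an amine or a carboxylic acid at either placement with the number held or lowered. From the compounds shown here alone, the effect of a longer chain on these two phenyl groups also remains open.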